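Methoxy on the core of compound 1: expected cytotoxicity

This account rests on a few compounds, and the source may have more. Where it says the series, first, only, none or still open, it means among the compounds named here.

Compound 1 `C[S+]([O-])/C=C/c1cc(=O)c2ccccc2o1` gives 8000 nM in a functional assay on DLD-1 cells (Homo sapiens) for cytotoxicity, with a stated time of 48 h; on this read-out lower numbers stand for stronger inhibition and higher numbers for weaker inhibition. Its number is the second highest of the three shown, though all three lie within the scatter of one another: compound 2 `CCC(=O)Oc1ccc2oc(/C=C/[S+](C)[O-])cc(=O)c2c1` gives 9000 nM and compound 3 `CCCCCOc1ccc2oc(/C=C/[S+](C)[O-])cc(=O)c2c1` gives 6600 nM. Compound 4 `COc1cccc2oc(/C=C/[S+](C)[O-])cc(=O)c12` differs from compound 1 by methoxy in place of hydrogen on an aromatic carbon. Going by the values given here, the steps that bear on this are the other substitutions on an aromatic carbon of the shared core, a 1.1-fold higher number from compound 1 to compound 2 (0.05 log units; within the scatter) and a 1.2-fold lower number from compound 1 to compound 3 (0.08 log units; within the scatter), and the exchange on the oxygen, a 1.4-fold lower number from compound 2 to compound 3 (0.13 log units; within the scatter); none went beyond the scatter. No step beyond the scatter is therefore expected in this assay. Compound 4 is estimated at 7500 nM, range 3500 nM to 16000 nM, which means an expected 1.1-fold lower number from compound 1 to compound 4 (0.03 log units; within the scatter).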

Compound 4, half-maximal inhibitory concentration: > 10000 nM
Compound 4: only a limit was reported; the forecaster's own chance of this, stated with the estimate: 10%; middle value at least 1.3-fold (0.12 log units) away from the limit.
By their numbers in this assay, from the lowest: compounds 3, 1 and 2 (each within the scatter of the next). At a limit, above all of these: compound 4.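

In this assay compound 4 gives > 10000 nM, which is a limit, so methoxy at this carbon, ortho to a fused ring, has no exact size here. The step is an at least 1.2-fold higher number from compound 1 to compound 4 (0.09 log units; that floor lies within the scatter), so its floor does not separate the two compounds. This is the only value in the series that ends at a limit: the limit of > 10000 nM in this assay, at which 1 of the 4 values shown sits.

On these data alone, whether the true step from hydrogen to methoxy lies beyond the scatter stays open. Also open, as far as these compounds go, is how an amine or a carboxylic acid on this same carbon would read out.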